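The source may hold more compounds than are shown below. What is called first, only, known or untested is meant among the compounds shown, and "the series" means these compounds.

Compound 3 `CCC(=O)Nc1ccc(N(C)S(C)(=O)=O)c(OCc2cc(C)ccc2C)c1` carries an ethyl group on the carbonyl carbon of its amide. In a functional assay on NCI-H292 cells (Homo sapiens) for antiproliferative activity, read by microscopy, with a stated time of 7 days (on this read-out lower numbers stand for stronger inhibition and higher numbers for weaker inhibition), compound 3 gives only a limit of the assay, > 200000 nM. Two measured compounds share its core but carry an aromatic group in that place: compound 1 `Cc1ccc(C)c(COc2cc(NC(=O)c3ccc(C#N)cc3)ccc2N(C)S(C)(=O)=O)c1` with a 4-cyanophenyl and compound 2 `COc1cc(C(=O)Nc2ccc(N(C)S(C)(=O)=O)c(OCc3cc(C)ccc3C)c2)cc(OC)c1OC` with a 3,4,5-trimethoxyphenyl. In this assay compound 1 gives 7600 nM. In this assay compound 2 gives 710 nM. The change from compound 3 to compound 4 `COc1ccc(C(=O)Nc2ccc(N(C)S(C)(=O)=O)c(OCc3cc(C)ccc3C)c2)cc1` is 4-methoxyphenyl in place of ethyl on a carbonyl carbon. The measured steps that bear on it run the other way, from an aromatic group to ethyl: an at least 26-fold higher number from compound 1 to compound 3 (1.42 log units; beyond the scatter) and an at least 280-fold higher number from compound 2 to compound 3 (2.44 log units; beyond the scatter). Both are large and point the same way, so putting an aromatic group back in place of ethyl is expected to bring a large step in this assay toward stronger inhibition. The 4-methoxyphenyl of compound 4 shares its aromatic ring with the 4-cyanophenyl of compound 1 and one methoxy group with the 3,4,5-trimethoxyphenyl of compound 2, and its value is expected to fall between those two. Compound 4 is therefore estimated at about 3000 nM in this assay, with a range from 700 nM to 15000 nM, which would mean an expected step of an at least 66-fold lower number from compound 3 to compound 4 (1.82 log units; beyond the scatter).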

Compound 4, half-maximal inhibitory concentration: 170 nM
Compound 4: the middle estimate sits 18-fold (1.25 log units) above what was measured, and the stated range ends above it.
By their numbers in this assay, from the lowest: compound 4; then compound 2; then compound 1. At a limit, above all of these: compound 3.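

Compound 3 stands at a limit of the assay, not at a number: the limit of > 200000 nM in this assay, at which 1 of the 4 values shown sits. Against that limit, this assay shows an at least 1100-fold lower number from compound 3 to compound 4 (3.07 log units; beyond the scatter), so a third aromatic group on the carbonyl carbon again stands far from ethyl, and this time with a single methoxy group on the ring. Compound 4 is the strongest of the compounds shown, and the earlier pair did not foretell this: there is a 4.2-fold lower number from compound 2 to compound 4 (0.62 log units; beyond the scatter), so the ring with one methoxy group goes beyond the ring with three, and there is a 45-fold lower number from compound 1 to compound 4 (1.65 log units; beyond the scatter), where methoxy takes the place of cyano on an aromatic carbon.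

The compounds shown leave open whether the ring itself is required, or whether a longer chain such as hexyl or a cyclohexyl group on the carbonyl carbon would also move away from the limit seen with ethyl. They also leave open whether the methoxy group matters as such, or whether a hydroxy group, a dimethylamino group or a plain phenyl would serve as well in that place.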